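A few compounds are considered here, and "the series" means these few. Any claim that something is new, unique, unknown or untested is made for them only; others in the source may bear on it.

- Compound 1 `CN1CCC(C(=O)N2Cc3c(NC(=O)C4CCC4)n[nH]c3C2(C)C)CC1`: > 225000 nM, a limit of the assay
- Compound 2 `CN1CCC(C(=O)N2Cc3c(NC(=O)c4ccc5ccccc5c4)n[nH]c3C2(C)C)CC1`: 219000 nM
- Compound 3 `CN1CCC(C(=O)N2Cc3c(NC(=O)c4ccc(C(F)(F)F)cc4)n[nH]c3C2(C)C)CC1`: 191000 nM

In a physicochemical assay for solubility, at pH 7 (a higher number here means a more soluble compound, a lower number a less soluble compound), compound 3 gives 191000 nM, within the scatter of compound 2 at 219000 nM. Compound 1 gives > 225000 nM, which is a limit and not a number.

Compound 4 `CCCNC(=O)Nc1n[nH]c2c1CN(C(=O)C1CCN(C)CC1)C2(C)C` differs from compound 3 at one place: propylamino in place of 4-(trifluoromethyl)phenyl on a carbonyl carbon. Three measured steps changed the group on this same carbonyl carbon: an at least 1.0-fold lower number from compound 1 to compound 2 (0.01 log units; that floor lies within the scatter), an at least 1.1-fold lower number from compound 1 to compound 3 (0.07 log units; that floor lies within the scatter) and a 1.1-fold lower number from compound 2 to compound 3 (0.06 log units; within the scatter). All three stay within the scatter, although the first two rest on a limit. No step beyond the scatter is therefore expected, and the estimated change is a 1.1-fold higher number from compound 3 to compound 4 (0.03 log units; within the scatter). For compound 4 the expected value is 205000 nM, with an estimated range of 130000 nM to 225000 nM.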

Compound 4, solubility: > 225000 nM
Compound 4: no number, only a limit (the forecaster's own chance of this, stated with the estimate: 40%); middle value at least 1.0-fold (0.04 log units) from the limit.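

In this assay, propylamino on this carbonyl carbon brings no drop in the number: the steps are an at least 1.1-fold higher number from compound 3 to compound 4 (0.07 log units; that floor lies within the scatter) and an at least 1.0-fold higher number from compound 2 to compound 4 (0.01 log units; that floor lies within the scatter). Compound 4 gives > 225000 nM, a limit of the assay and not a number, and its step with compound 1 cannot be read. This position therefore takes an open chain holding a nitrogen as well as the ring groups, though compound 1 and compound 4 both stop at the same limit: the limit of > 225000 nM in this assay, at which 2 of the 4 values shown sit.

On these data alone, how far compound 1 and compound 4 lie past that limit stays open. So does whether a carboxylic acid or a longer chain on this carbonyl carbon would move the number beyond the scatter.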